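The source may report more compounds than this note shows. Statements on the series, on what has been measured and on what is new or still open speak of the compounds shown alone.

Compound 1 `COc1ccc(NC(=O)/C(C#N)=C/c2cc(O)c(O)c([N+](=O)[O-])c2)cc1` gives 45.4 ug/mL in a functional assay on BGC-823 cells (Homo sapiens) for antiproliferative activity, read by MTT assay; on this read-out lower numbers stand for stronger inhibition and higher numbers for weaker inhibition. Compound 2 `N#C/C(=C\c1cc(O)c(O)c([N+](=O)[O-])c1)C(=O)Nc1cccc(Cl)c1` sits at the limit of > 100 ug/mL in this assay, at which 1 of the 3 values shown sits, reported as > 100 ug/mL and not as a number. Compound 3 `N#C/C(=C\c1cc(O)c(O)c([N+](=O)[O-])c1)C(=O)Nc1ccccc1Cl` gives 10.5 ug/mL and holds the lowest of the two numbers in hand; the step is a 4.3-fold lower number from compound 1 to compound 3 (0.64 log units; beyond the scatter), and an at least 2.2-fold higher number from compound 1 to compound 2 (0.34 log units; beyond the scatter) together with an at least 9.5-fold lower number from compound 2 to compound 3 (0.97 log units; beyond the scatter) show that the group on the amide nitrogen shifts this assay beyond the scatter in both directions. Compound 4 `N#C/C(=C\c1cc(O)c(O)c([N+](=O)[O-])c1)C(=O)N1CCOCC1` carries morpholin-4-yl in place of (2-chlorophenyl)amino on a carbonyl carbon. Among the measured compounds shown here, no measured step replaces the anilide by a cyclic amine; the three steps in hand only exchange substituted phenyl groups, so they bear on this change loosely, while the measured spread is wide. Compound 4 is expected to give a higher number, a 3.3-fold higher number from compound 3 to compound 4 (0.52 log units; beyond the scatter). The estimate for compound 4 in this assay is 35 ug/mL, with a range from 12 ug/mL to 100 ug/mL.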

Compound 4, half-maximal inhibitory concentration: > 100 ug/mL
Compound 4 was reported as a limit (the forecaster's own chance of this, stated with the estimate: 25%); middle value at least 2.8-fold (0.45 log units) from the limit.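

In this assay compound 4 gives > 100 ug/mL, a limit and not a number. Morpholin-4-yl in place of (2-chlorophenyl)amino on a carbonyl carbon gives an at least 9.5-fold higher number from compound 3 to compound 4 (0.97 log units; beyond the scatter), so this position is now seen to respond to a change away from a phenyl group, not only to changes on one. Compound 2 and compound 4 share one limit, and the step between them cannot be read: the limit of > 100 ug/mL in this assay, at which 2 of the 4 values shown sit.

From the compounds shown here alone, whether the step follows the loss of the amide hydrogen or of the aromatic ring stays open. A piperidin-1-yl or a benzylamino group on the carbonyl carbon would bear on this.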